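The source may report more compounds than this note shows. Statements on the series, on what has been measured and on what is new or still open speak of the compounds shown alone.

Compound 1 `CCCCCc1ccc(C#Cc2cn(CCC(COC(C)=O)COC(C)=O)c(=O)n(C(=O)c3ccccc3)c2=O)cc1` carries a 4-pentylphenyl group on a triple-bonded carbon. In a functional assay on SW-620 cells (Homo sapiens) for antiproliferative activity, read by MTT assay, with a stated time of 72 h (on this read-out lower numbers stand for stronger inhibition and higher numbers for weaker inhibition), compound 1 gives only a limit of the assay, > 100000 nM. Compound 2 `CC(=O)OCC(CCn1cc(C#CCc2ccccc2)c(=O)n(C(=O)c2ccccc2)c1=O)COC(C)=O` keeps the shared core but has benzyl in place of 4-pentylphenyl on the triple-bonded carbon, and in this assay compound 2 gives 36400 nM. That single change brought an at least 2.7-fold lower number from compound 1 to compound 2 (0.43 log units; beyond the scatter). Among the measured compounds shown here, compound 2 therefore holds the only plain number so far; the one other value shown is a limit, (the limit of > 100000 nM in this assay, at which 1 of the 2 values shown sits).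

Compound 3 `CCCCCC#Cc1cn(CCC(COC(C)=O)COC(C)=O)c(=O)n(C(=O)c2ccccc2)c1=O` differs from compound 2 by butyl in place of phenyl on a saturated chain carbon bound to a triple-bonded carbon. For the measured compounds named here, only the step from compound 1 to compound 2 offers guidance, and it sits on the triple-bonded carbon itself, whereas the new change lies one bond further out and removes the ring entirely rather than exchanging one aromatic group for another. The earlier step shows that a smaller group at this end can lower the number, but it says nothing about losing the ring altogether. A modest step at most is therefore expected, a 1.4-fold higher number from compound 2 to compound 3 (0.14 log units; within the scatter), and it may well fall within the scatter. Compound 3 is estimated at 50000 nM, with a range from 15000 nM to 150000 nM.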

Compound 3, half-maximal inhibitory concentration: 40700 nM
Compound 3: middle estimate off by 1.2-fold (0.09 log units), on the high side, and the stated range covers the measured number.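

In this assay, the ring at the far end of this side chain makes no difference that can be read: butyl in place of phenyl on a saturated chain carbon bound to a triple-bonded carbon gives a 1.1-fold higher number from compound 2 to compound 3 (0.05 log units; within the scatter), so benzyl and pentyl on the triple-bonded carbon cannot be told apart. Compound 3 also adds a comparison that compound 2 could not give. It keeps a pentyl chain while losing the ring of the 4-pentylphenyl group, and the change gives an at least 2.4-fold lower number from compound 1 to compound 3 (0.39 log units; beyond the scatter). Compound 1 has only a limit, so this step gives a minimum size and not a full one: the limit of > 100000 nM in this assay, at which 1 of the 3 values shown sits.

The compounds shown leave open whether a shorter chain such as propyl, a longer chain such as octyl, or a chain ending in an amine or a carboxylic acid on the triple-bonded carbon would move the number beyond the scatter. The rest of the shared core stays the same throughout, so its part in the read-out cannot be judged from these compounds.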